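Ester homologue of compound 1 on the shared core

The source may hold more compounds than are shown below. What is called first, only, known or untested is meant among the compounds shown, and "the series" means these compounds.

Compound 1 `Cc1ccc2oc(/C=C/[S+](C)[O-])cc(=O)c2c1`, compound 2 `CCC(=O)Oc1ccc2oc(/C=C/[S+](C)[O-])cc(=O)c2c1` and compound 3 `C[S+]([O-])/C=C/c1cc(=O)c2cc(Cl)ccc2o1` have all been run in a functional assay on DLD-1 cells (Homo sapiens) for cytotoxicity, with a stated time of 48 h; a higher number here means a weaker inhibitor, a lower number a stronger inhibitor. Compound 1 gives 7000 nM, the second highest of the three numbers. Compound 3 gives 6500 nM and compound 2 gives 9000 nM, each within the scatter of the value of compound 1. Compound 4 `CCCC(=O)Oc1ccc2oc(/C=C/[S+](C)[O-])cc(=O)c2c1` differs from compound 1 by (propylcarbonyl)oxy in place of methyl on an aromatic carbon. The measured step that bears most directly on this change is a 1.3-fold higher number from compound 1 to compound 2 (0.11 log units; within the scatter), which exchanges the same methyl for propanoyloxy. The steps of a 1.1-fold lower number from compound 1 to compound 3 (0.03 log units; within the scatter) and a 1.4-fold lower number from compound 2 to compound 3 (0.14 log units; within the scatter) likewise stay within the scatter. A step of a 1.3-fold higher number from compound 1 to compound 4 (0.11 log units; within the scatter) in this assay is therefore expected, with no movement beyond the scatter. Compound 4 is estimated to give 9000 nM, in a range from 4000 nM to 20000 nM.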

Compound 4, half-maximal inhibitory concentration: 8700 nM
Compound 4: the middle estimate sits 1.0-fold (0.01 log units) above what was measured, and the stated range covers the measured number.
By their numbers in this assay, from the lowest: compounds 3, 1, 4 and 2 (each within the scatter of the next).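

In this assay, extending the ester chain by one carbon leaves the number unmoved, with a 1.0-fold lower number from compound 2 to compound 4 (0.01 log units; within the scatter) as the step. The (propylcarbonyl)oxy group, with its 6 heavy atoms, also stays within the scatter against the smaller substituents, with a 1.2-fold higher number from compound 1 to compound 4 (0.09 log units; within the scatter) and a 1.3-fold higher number from compound 3 to compound 4 (0.13 log units; within the scatter), so the four compounds show no dependence on this substituent. Nothing available explains this flat result.

As far as these compounds go, whether a much longer chain, a free hydroxyl, an amine or a carboxylic acid on this aromatic carbon would move the number beyond the scatter remains open.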